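The source may hold more compounds than are shown below. What is called first, only, known or untested is meant among the compounds shown, and "the series" means these compounds.

Compound 1 `CNC(=O)c1cc(C(=O)NC2CC2)cc2c1OC[C@H]2c1ccccc1` and compound 3 `CNC(=O)c1cc(C(=O)NC)c2c(c1)[C@H](c1ccccc1)CO2` share a core, and in a physicochemical assay for lipophilicity, at pH 7.4 (on this read-out lower numbers stand for lower lipophilicity and higher numbers for higher lipophilicity), compound 1 gives 3.6 while compound 3 gives 3.2. Within the data shown here, the one change between them is methyl in place of cyclopropyl on an amide-type nitrogen; it made the step of a number 0.40 log units lower from compound 1 to compound 3 (beyond the scatter).

Compound 2 `CNC(=O)c1cc(C(=O)NC2CC2)cc2c1OC[C@@]2(C)c1ccccc1` stands on a different core, and the difference between the two cores is not broken down here. In this assay compound 2 gives 4, the highest of the three numbers, with compound 1 nearest and compound 3 furthest.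

Compound 4 `CNC(=O)c1cc(C(=O)NC)c2c(c1)[C@](C)(c1ccccc1)CO2` is not yet measured. Among the measured compounds shown here, it differs from compound 2 by methyl in place of cyclopropyl on an amide-type nitrogen, the same change as the one from compound 1 to compound 3, made on the same kind of place. For the measured compounds named here, only one measured example of this change exists, so the expectation rests on that single step. For compound 4 in this assay a step like a number 0.40 log units lower from compound 2 to compound 4 (beyond the scatter) is expected, because the same change produced a number 0.40 log units lower from compound 1 to compound 3 (beyond the scatter). On that basis compound 4 is estimated at 3.6, most likely between 3.3 and 3.9.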

Compound 4, distribution coefficient: 3.4
The estimate for compound 4 lay 0.20 log units above the measured number; the range from low to high includes it.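

In this assay methyl in place of cyclopropyl on an amide-type nitrogen now gives a number 0.60 log units lower from compound 2 to compound 4 (beyond the scatter) and so runs the same way as a number 0.40 log units lower from compound 1 to compound 3 (beyond the scatter) on the other core. This shows that the direction of the change carried over between these two cores, but two pairs cannot show that it would hold on any further core or that the size of the step is fixed from one core to the next. Nothing measured here explains why the step took the size it did on either core.

Only methyl and cyclopropyl appear on this amide-type nitrogen in the compounds shown, so it stays open how a longer chain such as butyl, or a group carrying an amine or a carboxylic acid, would read there. this assay is also the only read-out shown, so what the change does in any other kind of measurement stays open too.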